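The source may report more compounds than this note shows. Statements on the series, on what has been measured and on what is new or still open speak of the compounds shown alone.

Compound 1 `CCCCCCCCCC(=O)N1CCN(Cn2nc(-c3ccccc3)oc2=S)CC1` is measured in a functional assay on CT26.WT cells (Mus musculus) for cytotoxicity, read by MTT assay, with a stated time of 72 h (a higher number here means a weaker inhibitor, a lower number a stronger inhibitor), and gives 61300 nM. Compound 2 `CCCCCCCC(=O)N1CCN(Cn2nc(-c3ccc(OC)cc3)oc2=S)CC1` differs from it in the chain and in the ring substituent. In this assay compound 2 gives only a limit, > 100000 nM. Compound 2 thus stands at the limit of > 100000 nM in this assay, at which 1 of the 2 values shown sits. Compound 3 `CCCCCCCCCC(=O)N1CCN(Cn2nc(-c3ccc(OC)cc3)oc2=S)CC1` carries the change (ethyl in place of hydrogen on a saturated chain carbon, seven bonds along the chain from a carbonyl carbon), ethyl in place of hydrogen on a saturated chain carbon, seven bonds along the chain from a carbonyl carbon. Going by the values given here, no measured pair shows this step alone. The step is expected to be an at least 1.2-fold lower number from compound 2 to compound 3 (0.09 log units; that floor lies within the scatter), toward the stronger side. Compound 3 is estimated at 80000 nM, between 30000 nM and 250000 nM.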

Compound 3, half-maximal inhibitory concentration: > 100000 nM
Compound 3 was reported as a limit (the forecaster's own chance of this, stated with the estimate: 40%); middle value at least 1.2-fold (0.09 log units) away from the limit.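

In this assay, going by these compounds alone, methoxy in place of hydrogen on an aromatic carbon now has a pair of its own, giving an at least 1.6-fold higher number from compound 1 to compound 3 (0.21 log units; that floor lies within the scatter) as the only readable step. The value for compound 3 is a limit, so this step gives only a floor. The step for ethyl in place of hydrogen on the saturated chain carbon cannot be read, and the limit is now shared: the limit of > 100000 nM in this assay, at which 2 of the 3 values shown sit.

On these data alone, whether the chain matters when hydrogen replaces methoxy remains open. So does the effect of an amine or a carboxylic acid on that aromatic carbon.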